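The compounds below may be only part of what the source reports. "The series", "measured", "known", "first", "only" and "open" are said of these compounds alone.

Values in a functional assay on K562 cells (Homo sapiens) for inhibition (a higher number here means a weaker inhibitor of growth, a lower number a stronger inhibitor of growth), for the three measured compounds

Compound 1 `COc1cccc(/C=C/c2ccc(S(N)(=O)=O)cc2)c1` gives 20600 nM
Compound 2 `NS(=O)(=O)c1ccc(/C=C/c2ccc(F)cc2)cc1` gives 14900 nM
Compound 3 `NS(=O)(=O)c1ccc(/C=C/c2cccc(O)c2)cc1` gives 43400 nM

Compound 2 at 14900 nM and compound 1 at 20600 nM lie within the scatter of each other, so neither can be ranked ahead. Compound 3 at 43400 nM stands beyond the scatter from compound 2, with the higher number.

The unmeasured compound 4 `CN(C)c1ccc(/C=C/c2ccc(S(N)(=O)=O)cc2)cc1` differs from compound 2 by dimethylamino in place of fluoro on an aromatic carbon, para to a large group dimethylamino in place of fluoro on an aromatic carbon and nothing else.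

Going by the values given here, only one measured step bears on this, and only indirectly. Hydrogen in place of methyl on an oxygen on an aromatic ring gave a 2.1-fold higher number from compound 1 to compound 3 (0.32 log units; beyond the scatter) and that step is modest. Among the compounds with values here, it involves neither fluoro nor dimethylamino, and no measured compound carries dimethylamino, so the direction of the change stays open. Within the data shown here, the modest size of that one step is the only guide, and it points to no clear shift in this assay for this exchange, though the uncertainty is wide.

The expected change is a 1.1-fold lower number from compound 2 to compound 4 (0.06 log units; within the scatter) and so no step beyond the scatter is anticipated. For compound 4 the estimated value is 13000 nM with an expected range from 4500 nM to 36000 nM in this measurement.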

Compound 4, concentration for 50% growth inhibition: > 100000 nM
Compound 4 was reported as a limit; the forecaster's own chance of this, stated with the estimate: 7%; middle value at least 7.6-fold (0.88 log units) away from the limit.
By their numbers in this assay, from the lowest: compounds 2 and 1 (each within the scatter of the next); then compound 3. At a limit, above all of these: compound 4.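

The reading for compound 4 in this assay is a limit of the assay and not a number: the limit of > 100000 nM in this assay, at which 1 of the 4 values shown sits. Going by these compounds alone, the exchange of fluoro for dimethylamino, on an aromatic carbon para to a large group, gives an at least 6.7-fold higher number from compound 2 to compound 4 (0.82 log units; beyond the scatter), whereas the only earlier step, a change on an oxygen on an aromatic ring, gave a 2.1-fold higher number from compound 1 to compound 3 (0.32 log units; beyond the scatter). This shows that the group at this position can matter in this assay, and that dimethylamino here leaves the compound behind all three earlier compounds, which the modest earlier step gave no sign of.

The compounds shown leave open which feature of the exchange matters, since dimethylamino differs from fluoro both in its heavy atoms, with carbon and nitrogen entering, and in carrying a hydrogen-bond acceptor. An unsubstituted amine or a plain methyl group on this same aromatic carbon would help to separate these, and a bare hydrogen there would show whether fluoro itself contributes to the number of compound 2.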